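Swapping Trifluoromethyl for Chloro on a Diaryl Urea

The source may report more compounds than this note shows. Statements on the series, on what has been measured and on what is new or still open speak of the compounds shown alone.

compound 1 `COc1cc2cc(Oc3ccc(NC(=O)Nc4cccc(C(F)(F)F)c4)cc3)c(C)nc2cc1OC`: 21200 nM
compound 2 `COc1cc2cc(Oc3ccc(NC(=O)Nc4ccc(Cl)c(C(F)(F)F)c4)cc3)c(C)nc2cc1OC`: 10300 nM

In a functional assay on HOP-92 cells (Homo sapiens) for inhibition, read by sulforhodamine B assay, with a stated time of 48 h (a higher number here means that more compound is tolerated, a lower number that less compound is tolerated), compound 1 gives 21200 nM and compound 2 gives 10300 nM, so compound 2 stands at the lower of the two numbers. Among the compounds with values here, the single measured step, a 2.1-fold lower number from compound 1 to compound 2 (0.31 log units; beyond the scatter), concerns a different change. Compound 3 `COc1cc2cc(Oc3ccc(NC(=O)Nc4ccc(Cl)c(Cl)c4)cc3)c(C)nc2cc1OC` differs from compound 2 by chloro in place of trifluoromethyl on an aromatic carbon. Within the data shown here, no measured step bears directly on exchanging trifluoromethyl for chloro, so in this assay no change beyond the scatter is expected. The estimated step is a 1.3-fold higher number from compound 2 to compound 3 (0.10 log units; within the scatter). Compound 3 is expected to give about 13000 nM, within a range from 5000 nM to 35000 nM.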

Compound 3, concentration lethal to 50% of the cells: 14200 nM
Compound 3: the middle estimate sits 1.1-fold (0.04 log units) below what was measured; the range from low to high includes it.
By their numbers in this assay, from the lowest: compounds 2, 3 and 1 (each within the scatter of the next, the first and the last beyond it).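

In this assay, exchanging trifluoromethyl for chloro at this place, ortho to a chloro group, gives a step within the scatter (a 1.4-fold higher number from compound 2 to compound 3 (0.14 log units; within the scatter)). The step that replaces 3-(trifluoromethyl)phenyl with 3,4-dichlorophenyl also lies within the scatter (a 1.5-fold lower number from compound 1 to compound 3 (0.17 log units; within the scatter)), so these two steps show no clear effect of either change on this read-out. Nothing measured here offers an explanation for these small steps.

From the compounds shown here alone, whether a nitrile or a bromo group at this place would give a step beyond the scatter stays open. So does whether an amine or a carboxylic acid there would do so.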